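The compounds below may be only part of what the source reports. "The series", "measured", "known", "first", "only" and "open" are said of these compounds alone.

Within the data shown here, compound 1 `COc1ncnc2c1c(I)cn2[C@@H]1O[C@H](CO)[C@@H](O)[C@H]1O` stands as the only compound here with a measured number: in a functional assay on HL-60 cells (Homo sapiens) for antiproliferative activity, read by XTT assay, with a stated time of 72 h (a lower number here means a stronger inhibitor, a higher number a weaker inhibitor), compound 1 gives 2300 nM. Compound 2 `Nc1nc2c(c(-c3ccccc3)cn2[C@@H]2O[C@H](CO)[C@@H](O)[C@H]2O)c(=O)[nH]1` reaches only a limit of this assay, > 20000 nM. Compound 3 `CNc1ncnc2c1c(-c1ccsc1)cn2[C@@H]1O[C@H](CO)[C@@H](O)[C@H]1O` likewise stops at a limit, > 20000 nM. Both of those values sit at the limit of > 20000 nM in this assay, at which 2 of the 3 values shown sit. Compound 4 `COc1ncnc2c1c(-c1cc3ccccc3o1)cn2[C@@H]1O[C@H](CO)[C@@H](O)[C@H]1O`, not yet measured, differs from compound 1 in one place: 1-benzofuran-2-yl in place of iodo on an aromatic carbon. Among the measured compounds shown here, no measured pair here shows the effect of that exchange on its own; compounds 2 and 3 stop at limits, and each differs from compound 1 in more than this one place, so the size of the step is open. A moderate loss beyond the scatter is expected, a 3.5-fold higher number from compound 1 to compound 4 (0.54 log units; beyond the scatter). Compound 4 is therefore estimated at 8000 nM, within 2000 nM to 30000 nM.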

Compound 4, half-maximal inhibitory concentration: 4470 nM
Estimate against measurement, compound 4: 1.8-fold (0.25 log units) above; low and high end bracket the measured number.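

In this assay, 1-benzofuran-2-yl in place of iodo gives a 1.9-fold higher number from compound 1 to compound 4 (0.29 log units; within the scatter). On this aromatic carbon, then, a single iodine atom and a group of 9 heavy atoms with two aromatic rings cannot be told apart in this read-out. Compounds 2 and 3 differ from compound 1 in more than one place and stop at a limit, so they add no step that can be read: the limit of > 20000 nM in this assay, at which 2 of the 4 values shown sit.

From the compounds shown here alone, whether an amine or a carboxylic acid on this carbon would also leave the number within the scatter remains open.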